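Working notes: alkyl swap on a small inhibitor series

The source may hold more compounds than are shown below. What is called first, only, known or untested is meant among the compounds shown, and "the series" means these compounds.

Compound 1, `CC(C)(C)c1ncc(C(=O)Nc2cc(O)cc(Cl)c2)nc1Cl`, gives 99000 nM in a functional assay on the whole organism for inhibition, with Chlorella vulgaris as the target, read by spectrophotometry, with a stated time of 4 h; a higher number here means a weaker inhibitor, a lower number a stronger inhibitor. Compound 2, `CCCCc1cnc(C(=O)/C=C/c2ccccc2O)cn1`, gives 147000 nM in this assay. Compound 3, `CCCCc1cnc(C(=O)/C=C/c2ccc(O)cc2)cn1`, gives 265000 nM in this assay.

Compound 3 shows the highest number of the three. The step of a 1.8-fold higher number from compound 2 to compound 3 (0.26 log units; within the scatter) keeps compound 2 within the scatter of it, whereas compound 1 sits at a lower number, beyond the scatter.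

Compound 4, `CC(C)c1cnc(C(=O)/C=C/c2ccc(O)cc2)cn1`, differs from compound 3 by isopropyl in place of butyl on an aromatic carbon. For the measured compounds named here, none of the measured steps touches the alkyl on the core; the single measured step, a 1.8-fold higher number from compound 2 to compound 3 (0.26 log units; within the scatter), concerns the hydroxyphenyl only. No step beyond the scatter is therefore expected in this assay, and the expected step is no change at the digits printed from compound 3 to compound 4 (within the scatter). Compound 4 is estimated at 265000 nM, with a range from 120000 nM to 580000 nM.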

Compound 4, half-maximal inhibitory concentration: 279000 nM
Beside the measured number, compound 4's estimate is 1.1-fold (0.02 log units) below it; measured number inside the range.
By their numbers in this assay, from the lowest: compounds 1, 2, 3 and 4 (each within the scatter of the next, the first and the last beyond it).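

In this assay, isopropyl in place of butyl on the aromatic carbon next to the ring nitrogen gives a 1.1-fold higher number from compound 3 to compound 4 (0.02 log units; within the scatter). For the compounds shown here, this is the first measured step at the alkyl on the core, and with the 4-hydroxyphenyl held fixed, butyl and isopropyl cannot be told apart at this position. No measured evidence bears on this result.

On these data alone, it remains open whether a longer chain such as octyl, or an amine or a carboxylic acid, at this position would give a step beyond the scatter. As far as these compounds go, it also remains open whether the swap from butyl to isopropyl would read the same with the 2-hydroxyphenyl of compound 2.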